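Formyl to Hydroxymethyl Swap on Two Related Cores

The compounds below may be only part of what the source reports. "The series", "measured", "known", "first", "only" and "open" are said of these compounds alone.

Compound 1 `Cn1nc(Cc2nnc(SCCCCCCCC(=O)Nc3ccc(Cl)cc3Cl)n2CCC=O)c2ccccc2c1=O` was tested in an assay on NK92 cells for inhibition of interleukin-2 (Homo sapiens), read by AlphaScreen, with stated times of 30 min and 1 h (a lower number here means a stronger inhibitor, a higher number a weaker inhibitor), where compound 1 gives 960 nM. Compound 2 `Cn1nc(Cc2nnc(SCCCCCCCC(=O)Nc3ccc(Cl)cc3Cl)n2CCCO)c2ccccc2c1=O` differs from it by one change, (hydroxymethyl in place of formyl on a saturated chain carbon, two bonds along the chain from an aromatic nitrogen). In this assay compound 2 reaches only a limit, > 30000 nM. That change made an at least 31-fold higher number from compound 1 to compound 2 (1.49 log units; beyond the scatter). Compound 3 `Cn1c(Cc2nn(CCC=O)c(=O)c3ccccc23)nnc1SCC(=O)Nc1ccc(Cl)cc1Cl` has a core whose difference from the core of compound 1 is not broken down here. In this assay compound 3 also reaches only a limit, > 30000 nM. Compound 4 `Cn1c(Cc2nn(CCCO)c(=O)c3ccccc23)nnc1SCC(=O)Nc1ccc(Cl)cc1Cl` carries the same change made earlier, (hydroxymethyl in place of formyl on a saturated chain carbon, two bonds along the chain from an aromatic nitrogen), at the same place. The step that the limit leaves unreadable from compound 3 to compound 4 is expected to be unmeasurable, since compound 3 already sits at the limit and two of the three values shown sit there (the limit of > 30000 nM in this assay, at which 2 of the 3 values shown sit). Compound 4 is estimated at 60000 nM, most likely reported only as a limit.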

Compound 4, half-maximal inhibitory concentration: > 30000 nM
Compound 4: only a limit was reported (the forecaster's own chance of this, stated with the estimate: 85%); the middle value is on the limit's open side.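

Compound 3 and compound 4 both reach only a limit, so the step between them cannot be read: the limit of > 30000 nM in this assay, at which 3 of the 4 values shown sit. The compounds shown leave open whether swapping formyl for hydroxymethyl changes inhibition at all on this core.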